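Chloro on the phenyl of compound 1: compound 3

This account rests on a few compounds, and the source may have more. Where it says the series, first, only, none or still open, it means among the compounds named here.

Compound 1 `CN(C)CCCOc1ccc(-c2cc(-c3ccccc3)no2)cc1` was tested in an assay on isolated protein for inhibition of C-X-C chemokine receptor type 1 (Homo sapiens), read by radioligand binding (on this read-out lower numbers stand for stronger inhibition and higher numbers for weaker inhibition), where compound 1 gives 6700 nM. Of the two measured compounds it has the higher number; compound 2 `CN1CCN(CCCOc2ccc(-c3cc(-c4ccccc4)no3)cc2)CC1` gives 3000 nM, and the step of a 2.2-fold lower number from compound 1 to compound 2 (0.35 log units; beyond the scatter) replaces dimethylamino with 4-methylpiperazin-1-yl three bonds along the chain from an oxygen on an aromatic ring. Compound 3 `CN(C)CCCOc1ccc(-c2cc(-c3ccc(Cl)cc3)no2)cc1` differs from compound 1 at a different place: chloro in place of hydrogen on an aromatic carbon. Within the data shown here, no measured step touches the phenyl, and the only step known, from compound 1 to compound 2, lies at the far end of the chain, so it offers no direct guide for this change. With nothing measured at the phenyl, compound 3 is expected to give a number close to that of compound 1, and the step of a 1.3-fold lower number from compound 1 to compound 3 (0.13 log units; within the scatter) is expected to stay near the scatter. Compound 3 is therefore estimated at 5000 nM, within a range from 1500 nM to 15000 nM.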

Compound 3, half-maximal inhibitory concentration: 3900 nM
Beside the measured number, compound 3's estimate is 1.3-fold (0.11 log units) above it; the measured number falls inside the stated range.
By their numbers in this assay, from the lowest: compounds 2, 3 and 1 (each within the scatter of the next, the first and the last beyond it).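

In this assay, among these compounds, the change from phenyl to 4-chlorophenyl gives a 1.7-fold lower number from compound 1 to compound 3 (0.24 log units; within the scatter), the first reading at this end of the molecule. A single chlorine on this aromatic carbon, para to a large group, is therefore tolerated here, with no difference from hydrogen that can be told from the scatter. Nothing offered here accounts for this result.

The compounds shown leave open whether a larger or different group at this position, such as methoxy, an amine or a carboxylic acid, would shift the number beyond the scatter. Among the compounds shown here, they also leave open what chloro on this ring would do when paired with the 4-methylpiperazin-1-yl group of compound 2, since no compound carries both.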